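The compounds below may be only part of what the source reports. "The series", "measured", "known", "first", "only" and "open" are said of these compounds alone.

Working notes on the series. Compound 1 `O=C(CSc1nc(Nc2ccccc2)c2ccccc2n1)Nc1ccccc1F` and compound 2 `CCc1cccc(NC(=O)CSc2nc(Nc3ccccc3)c3ccccc3n2)c1` share one core and differ only in the aryl group on the amide-type nitrogen. In a functional assay on NCI-H1975 cells (Homo sapiens) for inhibition, read by MTT assay, with a stated time of 72 h (on this read-out higher numbers stand for weaker inhibition and lower numbers for stronger inhibition), compound 1 gives 9350 nM, and in this assay compound 2 gives 12000 nM. Going by the values given here, the step of a 1.3-fold higher number from compound 1 to compound 2 (0.11 log units; within the scatter) is the only measured step in the set, so compound 2 and compound 1 lie within the scatter of each other, and neither stands apart on the numbers so far.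

Compound 3 `COc1cccc(NC(=O)CSc2nc(Nc3ccccc3)c3ccccc3n2)c1` is the next member. It differs from compound 2 by methoxy in place of ethyl on an aromatic carbon. Among the compounds with values here, the one measured step in this assay, a 1.3-fold higher number from compound 1 to compound 2 (0.11 log units; within the scatter), bears on it only loosely, since it exchanged the aryl group as a whole rather than one substituent on it, and it stayed within the scatter. A methoxy-for-ethyl exchange has not been measured in this set. The expectation for compound 3 is therefore a step of a 1.1-fold lower number from compound 2 to compound 3 (0.04 log units; within the scatter) in this assay, that is, nothing beyond the scatter. Compound 3 is estimated at 11000 nM in this assay, with a range from 5000 nM to 25000 nM.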

Compound 3, half-maximal inhibitory concentration: 19400 nM
The estimate for compound 3 lay 1.8-fold (0.25 log units) below the measured number; the range from low to high includes it.
By their numbers in this assay, from the lowest: compounds 1, 2 and 3 (each within the scatter of the next, the first and the last beyond it).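

In this assay, methoxy in place of ethyl on the aromatic carbon gives a 1.6-fold higher number from compound 2 to compound 3 (0.21 log units; within the scatter), so this exchange, which adds one hydrogen-bond acceptor by the count of the two structures, does not resolve the pair on this read-out. Going by these compounds alone, the wider aryl exchange, 3-methoxyphenyl in place of 2-fluorophenyl on the amide-type nitrogen, gives a 2.1-fold higher number from compound 1 to compound 3 (0.32 log units; beyond the scatter), the first step in the set beyond the scatter, though a modest one, and so the first sign that the aryl group at this position can shift the number at all. Nothing available on these compounds accounts for either step.

Going by these compounds, it remains open whether a different kind of group at this place, such as an amine, a carboxylic acid or a longer chain like propoxy, would give a step well beyond the scatter. On these data alone, it is also open whether the modest step belongs to the methoxy group itself or to its place on the ring, as 2-fluorophenyl and 3-methoxyphenyl differ in both.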